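A basic azetidine replaces a hydroxyethyl on the benzylic amine

This account rests on a few compounds, and the source may have more. Where it says the series, first, only, none or still open, it means among the compounds named here.

Within the data shown here, compound 2 `CCC[C@@H](CO)Nc1nc(N)nc(C)c1Cc1ccc(CNCCO)cc1OC` is the only compound with a number in an assay on HEK293 cells for agonist activity at Toll-like receptor 8 (Homo sapiens); on this read-out higher numbers stand for an effect only at larger amounts of compound and lower numbers for an effect already at smaller amounts: there compound 2 gives 5370 nM. Compound 1 `CCC[C@@H](CCO)Nc1nc(N)nc(C)c1Cc1ccc(CN(C)CC(N)=O)cc1OC` gives > 10000 nM in this assay, which is a limit of the assay and not a number; the limit of > 10000 nM in this assay, at which 1 of the 2 values shown sits, describes this.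

Compound 3 `CCC[C@@H](CO)Nc1nc(N)nc(C)c1Cc1ccc(CNC2CN(C)C2)cc1OC` has not yet been measured in this assay. It differs from compound 2 by 1-methylazetidin-3-yl in place of 2-hydroxyethyl on an amine nitrogen. Among the measured compounds shown here, no two measured compounds differ in only one place, so no measured step exists to guide this change. The expectation is a step from compound 2 to compound 3 of a 1.8-fold lower number from compound 2 to compound 3 (0.25 log units; within the scatter), a shift toward lower values that may still fall within the usual scatter. Compound 3 is therefore expected to give about 3000 nM in this assay, with a plausible range from 800 nM to 12000 nM.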

Compound 3, half-maximal effective concentration: 6170 nM
Beside the measured number, compound 3's estimate is 2.1-fold (0.31 log units) below it, and the stated range covers the measured number.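

Among these compounds, this is the first step with a number at both ends, and it concerns the group on an amine nitrogen: in this assay, 1-methylazetidin-3-yl in place of 2-hydroxyethyl gives a 1.1-fold higher number from compound 2 to compound 3 (0.06 log units; within the scatter). At this position, then, an open chain with a hydroxyl and a small ring with a nitrogen give numbers that cannot be told apart, so the hydroxyl of 2-hydroxyethyl is not required to hold the read-out at this level. Nothing measured here gives a reason for this outcome.

From the compounds shown here alone, what stays open is whether any group on this nitrogen can move the number beyond the scatter at all. A longer chain ending in an amine, or one ending in a carboxylic acid, would put that question to the shared core.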